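A few compounds are considered here, and "the series" means these few. Any claim that something is new, unique, unknown or untested is made for them only; others in the source may bear on it.

Working notes on the series. The shared core of compound 1 `CCCc1cc(N)c2cc(NC(=O)CCc3ccccc3)ccc2n1` carries a saturated linker between the carbonyl and the phenyl ring; in an assay on isolated protein for displacement of a labelled ligand from melanin-concentrating hormone receptor 1 (Homo sapiens) (on this read-out higher numbers stand for weaker inhibition and lower numbers for stronger inhibition), compound 1 gives 8300 nM. Compound 2 `CCCc1cc(N)c2cc(NC(=O)/C=C/c3ccccc3)ccc2n1` replaces that linker with the 2-phenylethenyl group and gives 1000 nM, a step of an 8.3-fold lower number from compound 1 to compound 2 (0.92 log units; beyond the scatter). Compound 3 `CCCc1cc(N)c2cc(NC(=O)/C=C/c3ccc(C(C)(C)C)cc3)ccc2n1` adds a tert-butyl group on the phenyl ring and gives 22 nM, a step of a 45-fold lower number from compound 2 to compound 3 (1.66 log units; beyond the scatter). Among the three measured values, compound 2 therefore holds the middle position, separated from compound 1 and from compound 3 by steps that both lie beyond the scatter.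

Compound 4 `CCCc1cc(N)c2cc(NC(=O)/C=C/c3ccccc3Cl)ccc2n1` is not yet measured. It differs from compound 2 by chloro in place of hydrogen on an aromatic carbon. For the measured compounds named here, of the measured steps, only the one from compound 2 to compound 3 concerns a substituent on the same phenyl ring, and that step was large; the step from compound 1 to compound 2 concerns the linker and does not bear on this change. The chloro enters at a different place, ortho to a large group, and is far smaller than tert-butyl, so a smaller gain is expected. The expected step is a 2.9-fold lower number from compound 2 to compound 4 (0.46 log units; beyond the scatter). The value expected for compound 4 is 350 nM, with a range from 100 nM to 1200 nM.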

Compound 4, half-maximal inhibitory concentration: 120 nM
Compound 4: the middle estimate sits 2.9-fold (0.46 log units) above what was measured, within the range that was stated.
By their numbers in this assay, from the lowest: compound 3; then compound 4; then compound 2; then compound 1.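

In this assay, for the compounds shown here, the step of an 8.3-fold lower number from compound 2 to compound 4 (0.92 log units; beyond the scatter) shows that the phenyl ring of compound 2 responds to a substituent of only 1 heavy atom, ortho to a large group, whereas the only earlier change on this ring, a 45-fold lower number from compound 2 to compound 3 (1.66 log units; beyond the scatter), involved the much larger tert-butyl group. Phenyl to 2-chlorophenyl is therefore a second change on this ring that lowers the number beyond the scatter, and it does so with the chloro at a different place from the tert-butyl group of compound 3, so across these two compounds the lowering is tied neither to one place on the ring nor to a group as large as tert-butyl. No measurement at hand accounts for the size of this step.

Open, from the compounds shown here alone, is whether fluoro, bromo, methyl or methoxy at the same place would give a step of similar size, and whether chloro elsewhere on the ring would match it. Also open, going by these compounds, is whether chloro and tert-butyl together on one ring would add up, and whether the 2-chlorophenyl group would give a comparable step on the saturated linker of compound 1.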